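Swapping One Five-Membered Aromatic Ring for Another

The source may hold more compounds than are shown below. What is called first, only, known or untested is meant among the compounds shown, and "the series" means these compounds.

Measured so far:
compound 1, `c1ccc(-c2nc[nH]n2)c(NCC2=NCCN2)c1`: 100%
compound 2, `CCn1nccc1-c1ccccc1NCC1=NCCN1`: 0%

Two compounds share a core and differ only in the five-membered aromatic ring attached to it. In a functional assay with Alpha-1B adrenergic receptor (Homo sapiens) as the target, read by calcium flux (a higher number here means a larger maximal response, a lower number a smaller maximal response), compound 1 gives 100%, the higher of the two numbers. Compound 2 gives 0%, a result far below compound 1 and well beyond the usual scatter. Compound 2 carries a ring with an alkyl group on one of its ring nitrogens and no hydrogen-bond donor, while the ring of compound 1 has a free ring hydrogen.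

Compound 3, `Cn1ccnc1-c1ccccc1NCC1=NCCN1`, has not been measured. Relative to compound 1 the change is 1-methyl-1H-imidazol-2-yl in place of 1H-1,2,4-triazol-3-yl on an aromatic carbon. The ring that enters, 1-methyl-1H-imidazol-2-yl, again has a methyl group on a ring nitrogen and no hydrogen-bond donor, which in this respect resembles compound 2 more than compound 1. Among the measured compounds shown here, a large downward step is therefore expected, a number 80 percentage points lower from compound 1 to compound 3 (beyond the scatter), because compound 2 gives 0% in this assay and is the only comparable compound. For compound 3 the expected maximal response is 20%, within a range from 0% to 60%.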

Compound 3, largest response reached (reported as maximal response), in percent of the reference or control that the assay uses: 104%
Compound 3: middle estimate off by 84 percentage points, on the low side; the whole stated range lies below it.
By their numbers in this assay, from the lowest: compound 2; then compounds 1 and 3 (each within the scatter of the next).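

The 1-methyl-1H-imidazol-2-yl group has 0 hydrogen-bond donors and the 1H-1,2,4-triazol-3-yl group has 1, yet in this assay this change on an aromatic carbon gives a number 4 percentage points higher from compound 1 to compound 3 (within the scatter), so the two rings cannot be told apart in this read-out. A free ring hydrogen is therefore not required for a full response at this position, and a methyl group on a ring nitrogen is compatible with one, which compound 2 alone could not reveal: compound 2 gives 0%, while compound 3, which shares both of these features, gives 104%. Nothing available here explains why compound 1 and compound 3 behave alike or why compound 2 differs so sharply from them.

From the compounds shown here alone, what separates compound 2 from compound 3 remains open, since their rings differ both in the alkyl group and in how the ring atoms are arranged. A 1-ethyl-1H-imidazol-2-yl or a 1-methyl-1H-pyrazol-5-yl group would pull those two differences apart, and a plain phenyl ring would test whether this position needs ring nitrogens at all.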